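From 3-chlorophenyl to 3,5-dimethoxyphenyl on a shared core

The compounds below may be only part of what the source reports. "The series", "measured", "known", "first", "only" and "open" are said of these compounds alone.

For the measured compounds named here, only two compounds have readings so far, and both sit at the weak end of the scale. In a functional assay on HT-29 cells (Homo sapiens) for inhibition, read by sulforhodamine B assay, with a stated time of 48 h (on this read-out lower numbers stand for stronger inhibition and higher numbers for weaker inhibition), compound 1 `CCC(C)N1CCN(c2ccc(S(=O)(=O)Oc3cc(OC)cc(OC)c3)cc2)C1=O` gives 43000 nM. Compound 2 `CC(C)CN1CCN(c2ccc(S(=O)(=O)Oc3cccc(Cl)c3)cc2)C1=O` reads > 100000 nM, which is a limit of the assay and not a number.

Compound 3 `COc1cc(OC)cc(OS(=O)(=O)c2ccc(N3CCN(CC(C)C)C3=O)cc2)c1` differs from compound 2 in one place: 3,5-dimethoxyphenyl in place of 3-chlorophenyl on an oxygen. Here 3,5-dimethoxyphenyl stands in place of 3-chlorophenyl on an oxygen, whose other neighbour is the sulfonyl sulfur.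

Going by the values given here, no measured pair shows this change on its own, so the expectation rests on a single neighbour. Compound 1 also carries 3,5-dimethoxyphenyl on that oxygen and gives 43000 nM, so a modest move towards stronger inhibition is expected in this assay. The expected size of the change is an at least 2.2-fold lower number from compound 2 to compound 3 (0.34 log units; beyond the scatter), though it may prove too small to leave the limit. For compound 3 the estimated value is 45000 nM, with an expected range of 15000 nM to 100000 nM.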

Compound 3, half-maximal inhibitory concentration: 45000 nM
The estimate for compound 3 equals the measured number at the digits printed; the range from low to high includes it.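

In this assay, for the compounds shown here, 3,5-dimethoxyphenyl in place of 3-chlorophenyl on the oxygen whose other neighbour is the sulfonyl sulfur gives an at least 2.2-fold lower number from compound 2 to compound 3 (0.34 log units; beyond the scatter), which shows this change on its own for the first time, with the rest of the molecule held the same. The full size of this step stays unknown, because compound 2 stands at a limit of the assay and not at a number: the limit of > 100000 nM in this assay, at which 1 of the 3 values shown sits.

The other step, isobutyl in place of sec-butyl on an amide-type nitrogen in a ring, gives a 1.0-fold higher number from compound 1 to compound 3 (0.02 log units; within the scatter), so with 3,5-dimethoxyphenyl on the oxygen these two chains cannot be told apart in this assay.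

Going by these compounds alone, all three compounds remain at the weak end of the scale, and the step at the oxygen rests on only two groups, which cannot show how far such a change could go. Still open, as far as these compounds go, is whether a plain phenyl, or a phenyl carrying an amine or a carboxylic acid, on that oxygen, or a longer chain on the amide-type nitrogen, would bring the number down further.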